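The source may hold more compounds than are shown below. What is called first, only, known or untested is meant among the compounds shown, and "the series" means these compounds.

Measured in a functional assay on Vero cells (Chlorocebus sabaeus) for inhibition; a lower number here means a stronger inhibitor, a higher number a weaker inhibitor:
Compound 1 `CNc1ncnc2c1ncn2[C@@H]1CS[C@@H](CO)O1` gives > 100000 nM (a limit)
Compound 2 `CNc1ncnc2c1ncn2[C@H]1CS[C@@H](CO)O1` gives > 100000 nM (a limit)

Compound 2 therefore has no number, only the limit > 100000 nM of the assay. Compound 3 `Nc1ncnc2c1ncn2[C@H]1CS[C@@H](CO)O1` has hydrogen in place of methyl on a nitrogen on an aromatic ring, a change counted as hydrogen in place of methyl on a nitrogen on an aromatic ring here. Within the data shown here, the one measured step, a step that the two limits leave unreadable from compound 1 to compound 2, bears on it only weakly, and the fact that compounds 1 and 2 differ only in the configuration as drawn shows that it concerns configuration and leaves this methyl untouched. It offers no size to carry over. Among the measured compounds shown here, what remains is the limit of > 100000 nM in this assay, at which 2 of the 2 values shown sit, as the only guide. No step beyond the scatter is therefore expected in this assay, and no direction can be argued with confidence. The expected step is a number no higher from compound 2 to compound 3 (the limit leaves the size open) as estimated here. Compound 3 is expected at about 100000 nM with an estimated range of 30000 nM to 200000 nM in this reading.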

Compound 3, half-maximal inhibitory concentration: > 100000 nM
Compound 3: only a limit was reported; the forecaster's own chance of this, stated with the estimate: 70%; the middle value sits exactly at the limit.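

In this assay compound 3 gives > 100000 nM, which is a limit and not a number. Among these compounds, compound 2 also stands only at a limit, so no step from it to compound 3 can be read. The compounds shown leave open whether methylamino to amino, or the configuration, changes inhibition at all.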